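The compounds below may be only part of what the source reports. "The series", "measured", "known", "first", "only" and "open" are said of these compounds alone.

Compound 1 `CC1(C)c2[nH]nc(NC(=O)c3ccccc3)c2CN1Cc1cccc(Cl)c1` and compound 2 `CC1(C)c2[nH]nc(NC(=O)c3ccc4ncccc4c3)c2CN1Cc1cc(F)cc(F)c1` share one core and differ at two places. In an assay on Sf21 cells for inhibition of high affinity nerve growth factor receptor (Homo sapiens), read by HTRF, with a stated time of 30 min, in the presence of a further agent that is not named here (on this read-out higher numbers stand for weaker inhibition and lower numbers for stronger inhibition), compound 1 gives 670 nM, while in this assay compound 2 gives 180 nM, the lowest of the two numbers and beyond the scatter from compound 1. Compound 3 `CC1(C)c2[nH]nc(NC(=O)c3ccc(F)cc3)c2CN1Cc1cc(F)cc(F)c1` differs from compound 2 in one place: 4-fluorophenyl in place of quinolin-6-yl on a carbonyl carbon. Among the measured compounds shown here, no single-change step between measured compounds is known, so the size of this change is uncertain. Compound 3 is expected to give a somewhat higher number, a step of a 2.5-fold higher number from compound 2 to compound 3 (0.40 log units; beyond the scatter). Compound 3 is estimated at 450 nM, within a range from 150 nM to 1300 nM.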

Compound 3, half-maximal inhibitory concentration: 350 nM
Beside the measured number, compound 3's estimate is 1.3-fold (0.11 log units) above it; the range from low to high includes it.
By their numbers in this assay, from the lowest: compounds 2, 3 and 1 (each within the scatter of the next, the first and the last beyond it).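

On the carbonyl carbon, 4-fluorophenyl in place of quinolin-6-yl gives a 1.9-fold higher number from compound 2 to compound 3 (0.29 log units; within the scatter) in this assay. Among the compounds shown here, this is the first single change that can be read, and in this pair a smaller group with one aromatic ring in place of two leaves the number within the scatter. Nothing given here explains this result.

As far as these compounds go, whether an amine or a carboxylic acid on this aromatic ring would shift the number remains open. So does the effect of the second place at which compound 1 differs from compound 2.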